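The compounds below may be only part of what the source reports. "The series", "measured", "known", "first", "only" and "open" are said of these compounds alone.

Three compounds measured in a functional assay on SW-620 cells (Homo sapiens) for inhibition, read by MTT assay, with a stated time of 48 h (a higher number here means a weaker inhibitor, a lower number a stronger inhibitor), set the scene. Compound 1 `Cc1ccc(NC(=S)NC(=O)c2ccc(OCc3ccccc3F)cc2)cc1-c1nc2ccccc2[nH]1` gives 6440 nM, compound 2 `O=C(NC(=S)Nc1ccc(Cl)c(-c2nc3ccccc3[nH]2)c1)c1ccc(OCc2ccc(Cl)cc2Cl)cc1` gives 50200 nM, and compound 3 `Cc1ccc(NC(=O)NC(=O)c2ccc(OCc3ccccc3)cc2)cc1-c1nc2ccccc2[nH]1` gives 30100 nM. Compound 3 therefore holds the second highest of the three numbers; its gap to compound 2 lies within the scatter, while compound 1 stands clearly apart with a lower number. Compound 4 `Cc1ccc(NC(=O)NC(=O)c2ccc(OCc3ccccc3Cl)cc2)cc1-c1nc2ccccc2[nH]1` is not yet measured. It differs from compound 3 by chloro in place of hydrogen on an aromatic carbon, a chloro in place of hydrogen on an aromatic carbon, at the position cut one bond further out read as benzyloxy to (2-chlorobenzyl)oxy. Going by the values given here, no measured pair shows this step directly. Compound 4 is expected to give 20000 nM, within 6000 nM to 60000 nM. The expected step of a 1.5-fold lower number from compound 3 to compound 4 (0.18 log units; within the scatter) is estimated to stay within the scatter.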

Compound 4, half-maximal inhibitory concentration: 35700 nM
Beside the measured number, compound 4's estimate is 1.8-fold (0.25 log units) below it; low and high end bracket the measured number.
By their numbers in this assay, from the lowest: compound 1; then compounds 3, 4 and 2 (each within the scatter of the next).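

Turning benzyloxy into (2-chlorobenzyl)oxy gives a 1.2-fold higher number from compound 3 to compound 4 (0.07 log units; within the scatter) in this assay, the first step read directly at this position. Chloro in place of hydrogen on this aromatic carbon therefore does not separate the two compounds beyond the scatter. No measurement shown here accounts for this result. Going by these compounds, what remains open is whether a larger or different group at this position, such as a methoxy group, an amine or a carboxylic acid, would give a number beyond the scatter from that of compound 3.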